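A few compounds are considered here, and "the series" means these few. Any claim that something is new, unique, unknown or untested is made for them only; others in the source may bear on it.

Compound 1 `C[C@]1(C(=O)O)CC[C@H](C(=O)N2CC[C@](c3ccc(C(F)(C(F)(F)F)C(F)(F)F)cc3)(S(=O)(=O)c3ccc(F)cc3)C2)CC1` gives 93%
Compound 2 `CO[C@]1(C(=O)N2CC[C@](c3ccc(C(F)(C(F)(F)F)C(F)(F)F)cc3)(S(=O)(=O)c3ccc(F)cc3)C2)CC[C@H](C(=O)O)CC1` gives 95%
Compound 3 `NC(=O)[C@H]1CC[C@H](C(=O)N2CC[C@](c3ccc(C(F)(C(F)(F)F)C(F)(F)F)cc3)(S(=O)(=O)c3ccc(F)cc3)C2)CC1` gives 100%

In an ADME assay on microsomes from liver (Mus musculus) for metabolic stability, with a stated time of 10 min (a higher number here means that more of the compound is left, a lower number that less of the compound is left), compound 3 stands at 100% and lies within the scatter of both other compounds. Compound 4 `O=C(N1CC[C@](c2ccc(C(F)(C(F)(F)F)C(F)(F)F)cc2)(S(=O)(=O)c2ccc(F)cc2)C1)C1(O)CCS(=O)(=O)CC1` keeps the shared core and changes the group on the carbonyl carbon: 4-hydroxy-1,1-dioxothian-4-yl in place of 4-carbamoylcyclohexyl on a carbonyl carbon. Within the data shown here, three measured steps bear on this place: a number 7 percentage points higher from compound 1 to compound 3 (within the scatter) and a number 5 percentage points higher from compound 2 to compound 3 (within the scatter) and a number 2 percentage points higher from compound 1 to compound 2 (within the scatter). All three are small, but none brings in the 4-hydroxy-1,1-dioxothian-4-yl group, so the support is indirect. No change beyond the scatter is therefore expected, and the estimated step is a number 7 percentage points lower from compound 3 to compound 4 (within the scatter). For compound 4 the expected value is 93%, with an estimated range of 80% to 100%.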

Compound 4, percent of the compound remaining: 90%
Compound 4: the middle estimate sits 3 percentage points above what was measured; measured number inside the range.
By their numbers in this assay, from the lowest: compounds 4, 1, 2 and 3 (each within the scatter of the next).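

With a number 10 percentage points lower from compound 3 to compound 4 (within the scatter) and a number 5 percentage points lower from compound 2 to compound 4 (within the scatter) and a number 3 percentage points lower from compound 1 to compound 4 (within the scatter) in this assay the position on the carbonyl carbon now also accepts a ring with a hetero atom, not only a cyclohexyl ring. Among these compounds, compound 4 carries neither a carboxy nor a carbamoyl group, and still no step here leaves the scatter. No measurement given here accounts for this result. The compounds shown leave open what an amine in place of the hydroxy group would do, and whether any group at this position moves the number beyond the scatter.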